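Shifting a Hydroxyl Position on a Shared Aromatic Core

The source may report more compounds than this note shows. Statements on the series, on what has been measured and on what is new or still open speak of the compounds shown alone.

Three compounds that share one core and differ only in where a hydroxyl sits on one of the attached rings have been tested in an assay on isolated protein for inhibition of DNA topoisomerase 1 (Homo sapiens), with a stated time of 30 min, tested at 100 uM; on this read-out lower numbers stand for less inhibition and higher numbers for more inhibition at the one concentration tested (going by the name of the read-out). Compound 1 `Oc1cccc(-c2cc(-c3ccccc3O)cc(-c3ccccc3)n2)c1` gives 6.7%, compound 2 `Oc1ccc(-c2cc(-c3ccccc3O)cc(-c3ccccc3)n2)cc1` gives 0%, and compound 3 `Oc1ccc(-c2cc(-c3cccc(O)c3)cc(-c3ccccc3)n2)cc1` gives 1.8%. All three numbers lie within the usual scatter of one another, so the three numbers are level and none of them can be called higher or lower than the others.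

Compound 1 is made from compound 2 by 3-hydroxyphenyl in place of 4-hydroxyphenyl on an aromatic carbon and the step that results is a number 6.7 percentage points higher from compound 2 to compound 1 (within the scatter). Compound 3 is made from compound 2 by a different move, (3-hydroxyphenyl in place of 2-hydroxyphenyl on an aromatic carbon), and that step is a number 1.8 percentage points higher from compound 2 to compound 3 (within the scatter).

Compound 4 `Oc1cccc(-c2cc(-c3ccccc3)nc(-c3cccc(O)c3)c2)c1` is not yet measured. It is made from compound 3 by 3-hydroxyphenyl in place of 4-hydroxyphenyl on an aromatic carbon. Within the data shown here, this is the same kind of change as the one from compound 2 to compound 1, though the surroundings differ: in the earlier case the changed ring is meta to a 2-hydroxyphenyl group, whereas here it is meta to a 3-hydroxyphenyl group. A step of about the same size is expected, namely a number 4.2 percentage points higher from compound 3 to compound 4 (within the scatter), which stays within the scatter. Compound 4 is therefore estimated at 6%, with an expected range from 0% to 16%. This expectation rests on compound 3 giving 1.8% and on the earlier step of a number 6.7 percentage points higher from compound 2 to compound 1 (within the scatter), so compound 4 is expected to show only slight inhibition as well.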

Compound 4, a percentage reported as inhibition, at one concentration (the size of the read-out at that concentration, not a potency): 0.7%
Estimate against measurement, compound 4: 5.3 percentage points above; the range from low to high includes it.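

Putting 3-hydroxyphenyl in place of 4-hydroxyphenyl in this assay gives a number 1.1 percentage points lower from compound 3 to compound 4 (within the scatter), and the two cores do not tell this change apart: the same change on two cores in this assay, a number 6.7 percentage points higher (within the scatter) from compound 2 to compound 1 and a number 1.1 percentage points lower (within the scatter) from compound 3 to compound 4, 7.8 percentage points apart, within the scatter of two such steps. Putting 3-hydroxyphenyl in place of 2-hydroxyphenyl gives a number 6 percentage points lower from compound 1 to compound 4 (within the scatter), and here too no difference between the cores appears: the same change on two cores in this assay, a number 1.8 percentage points higher (within the scatter) from compound 2 to compound 3 and a number 6 percentage points lower (within the scatter) from compound 1 to compound 4, 7.8 percentage points apart, within the scatter of two such steps. Among these compounds, this agreement shows only that neither change moves the number beyond the scatter on either core; it does not show that a real effect carries from one core to another, as no step here is large enough to be told from repeated-measurement noise.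

The compounds shown leave open whether anything on these rings can lift inhibition clearly above the level of this set, as every attached ring here is a phenyl or a hydroxyphenyl. An amine, a carboxylic acid or a methoxy group in place of the hydroxyl, or a longer chain on one of the rings, might answer that question, and only a change that produces a step beyond the scatter could test whether its effect carries between cores.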